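Sulfone hydroxamate series: removing the nitro group

This account rests on a few compounds, and the source may have more. Where it says the series, first, only, none or still open, it means among the compounds named here.

compound 1 `O=C(Nc1ccc(S(=O)(=O)C2CCC[C@@H]2C(=O)NO)cc1)c1ccccc1` — 47 nM
compound 2 `O=C(Nc1ccc(S(=O)(=O)C2CCC[C@@H]2C(=O)NO)cc1)c1ccc([N+](=O)[O-])cc1` — 0.122 nM
compound 3 `O=C(NCc1ccc(C(=O)Nc2ccc(S(=O)(=O)C3CCC[C@@H]3C(=O)NO)cc2)cc1)OCc1ccccc1` — 35 nM

All three were run in an assay on isolated protein for inhibition of matrix metalloproteinase-9 (Homo sapiens), read by fluorescence, with stated times of 5 min and 30 min; on this read-out higher numbers stand for weaker inhibition and lower numbers for stronger inhibition. Compound 2 stands lowest of the three numbers in this assay; the nearest is compound 3, the furthest compound 1, and both gaps lie beyond the scatter. Compound 1 and compound 3 sit within the scatter of each other.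

Compound 4 `O=C(Nc1ccc(S(=O)(=O)C2CCC[C@@H]2C(=O)NO)cc1)OCc1ccccc1` is not yet measured. It differs from compound 2 by benzyloxy in place of 4-nitrophenyl on a carbonyl carbon. The relevant precedent is the step from compound 1 to compound 2, a 390-fold lower number from compound 1 to compound 2 (2.59 log units; beyond the scatter), which shows what the nitro group contributes on this core; in compound 4 that group is gone. The step from compound 2 to compound 3, a 290-fold higher number from compound 2 to compound 3 (2.46 log units; beyond the scatter), points the same way: once the nitro is absent, the number returns to the range of compound 1 and compound 3, whatever else sits on the carbonyl carbon. A large step upward is therefore expected for compound 4, a 410-fold higher number from compound 2 to compound 4 (2.61 log units; beyond the scatter), back into the range of compound 1 and compound 3. The estimate for compound 4 in this assay is 50 nM, with a range from 10 nM to 250 nM.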

Compound 4, half-maximal inhibitory concentration: 520 nM
Beside the measured number, compound 4's estimate is 10-fold (1.02 log units) below it; the measured number lies above the stated range.
By their numbers in this assay, from the lowest: compound 2; then compounds 3 and 1 (each within the scatter of the next); then compound 4.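

In this assay, the group on the carbonyl carbon matters even without a nitro group: benzyloxy in place of phenyl gives an 11-fold higher number from compound 1 to compound 4 (1.04 log units; beyond the scatter), whereas the ((benzyloxycarbonyl)amino)methyl group on the aromatic carbon left compound 3 within the scatter of compound 1. Benzyloxy in place of 4-nitrophenyl gives a 4300-fold higher number from compound 2 to compound 4 (3.63 log units; beyond the scatter), a step that goes past the level of compound 1, so losing the nitro group does not by itself set the number reached, and the values of compound 1 and compound 3 do not bound the nitro-free members of the series. Nothing at hand accounts for the weaker inhibition seen with benzyloxy on this carbonyl carbon.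

From the compounds shown here alone, whether a nitro group on the aromatic ring of the benzyloxy group would recover the low numbers of compound 2 remains open. Also open, going by these compounds, is whether the effect of nitro on the phenyl of the core of compound 1 extends to other groups on that aromatic carbon, such as an amine, a nitrile or a carboxylic acid.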